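A few compounds are considered here, and "the series" means these few. Any claim that something is new, unique, unknown or untested is made for them only; others in the source may bear on it.

In a functional assay (trachea) with Cavia porcellus as the target (a lower number here means a stronger inhibitor, a higher number a weaker inhibitor), three compounds that share one core and differ only in the chain on an aromatic nitrogen have been measured. Compound 1 `CC(C)=CCn1nc(-c2cccnc2)c2ccccc2c1=O` gives 1380 nM, compound 2 `CCOC(=O)Cn1nc(-c2cccnc2)c2ccccc2c1=O` gives 43700 nM, and compound 3 `CCOC(=O)CCCn1nc(-c2cccnc2)c2ccccc2c1=O` gives 10000 nM, the second highest of the three numbers. Compound 4 `O=c1c2ccccc2c(-c2cccnc2)nn1CCSc1nccs1` departs from compound 3 through one change: (1,3-thiazol-2-yl)sulfanyl in place of (ethoxycarbonyl)methyl on a saturated chain carbon, two bonds along the chain from an aromatic nitrogen. In words, (1,3-thiazol-2-yl)sulfanyl stands in place of (ethoxycarbonyl)methyl on a saturated chain carbon, two bonds along the chain from an aromatic nitrogen.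

Among the compounds with values here, no measured step makes this exchange, so the evidence is indirect. The closest guide is a 7.2-fold higher number from compound 1 to compound 3 (0.86 log units; beyond the scatter), a modest step that also removes the ethoxycarbonyl group. The large 32-fold higher number from compound 1 to compound 2 (1.50 log units; beyond the scatter) and the modest 4.4-fold lower number from compound 2 to compound 3 (0.64 log units; beyond the scatter) show that changes in this chain can move the number well beyond the scatter. Within the data shown here, both compounds carrying ethoxycarbonyl lie at higher numbers than compound 1, but that chain differs from the one in compound 4, so the direction remains tentative. A modest step to a lower number is therefore expected in this assay. The estimate corresponds to an expected 2.2-fold lower number from compound 3 to compound 4 (0.35 log units; beyond the scatter). For compound 4 the estimated value is 4500 nM, with an expected range from 1000 nM to 20000 nM.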

Compound 4, half-maximal inhibitory concentration: 10500 nM
Compound 4: the middle estimate sits 2.3-fold (0.37 log units) below what was measured, within the range that was stated.
By their numbers in this assay, from the lowest: compound 1; then compounds 3 and 4 (each within the scatter of the next); then compound 2.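

In this assay, putting (1,3-thiazol-2-yl)sulfanyl in place of (ethoxycarbonyl)methyl gives a 1.1-fold higher number from compound 3 to compound 4 (0.02 log units; within the scatter), so at this place, on a saturated chain carbon, two bonds along the chain from an aromatic nitrogen, an open ester chain and a five-membered aromatic ring are not told apart. Ethoxycarbonyl is thus not required for a number at this level, yet a chain without it does not by that alone match compound 1, as a 7.6-fold higher number from compound 1 to compound 4 (0.88 log units; beyond the scatter) shows, while compound 2 remains well separated, with a 4.2-fold lower number from compound 2 to compound 4 (0.62 log units; beyond the scatter). Nothing measured here explains these results, and no supporting evidence accompanies them.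

The compounds shown leave open whether the sulfur link or the thiazole ring matters more in compound 4, since neither is varied alone, and a phenyl ring on the same sulfur would separate the two. They also leave open how a terminal amine or carboxylic acid, or a longer chain ending in the thiazole, would compare with compound 4 in this assay.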